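Series notes: naphthalen-2-yl in place of 4-methylphenyl

A few compounds are considered here, and "the series" means these few. Any claim that something is new, unique, unknown or untested is made for them only; others in the source may bear on it.

Of the compounds shown here, three on one shared core have been measured in a functional assay on A549 cells (Homo sapiens) for antiproliferative activity, read by MTT assay, with a stated time of 72 h; a higher number here means a weaker inhibitor, a lower number a stronger inhibitor. Compound 1 `Fc1ccc(-c2csc(N3N=C(c4ccc(N5CCCCC5)cc4)CC3c3ccc(Cl)cc3)n2)cc1` gives 70200 nM. Compound 2 `FC(F)(F)c1ccc(-c2csc(N3N=C(c4ccc(N5CCCCC5)cc4)CC3c3ccc(Cl)cc3)n2)cc1` gives 42000 nM. Compound 3 `Cc1ccc(-c2csc(N3N=C(c4ccc(N5CCCCC5)cc4)CC3c3ccc(Cl)cc3)n2)cc1` returns only a limit of the assay, > 100000 nM, so no number is known for it. Its place among the three follows from the steps: an at least 2.3-fold higher number from compound 2 to compound 3 (0.37 log units; beyond the scatter); an at least 1.4-fold higher number from compound 1 to compound 3 (0.15 log units; that floor lies within the scatter); and a 1.7-fold lower number from compound 1 to compound 2 (0.22 log units; within the scatter).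

Compound 4 `Clc1ccc(C2CC(c3ccc(N4CCCCC4)cc3)=NN2c2nc(-c3ccc4ccccc4c3)cs2)cc1` is not yet measured. It differs from compound 3 by naphthalen-2-yl in place of 4-methylphenyl on an aromatic carbon. Going by the values given here, none of the measured steps makes a change of this kind; all three exchange one small group on the same aryl ring, and they bear on the new step only in showing that such exchanges shift this assay modestly at most. Among the compounds with values here, the ring enlargement in compound 4 has no measured counterpart here, so its direction cannot be read from the series, and a step of small to modest size in either direction is the working expectation, with a real chance that compound 4 again returns only a limit.

Compound 4 is expected to give 80000 nM, within a range from 20000 nM to 300000 nM. The expected step is an at least 1.2-fold lower number from compound 3 to compound 4 (0.09 log units; that floor lies within the scatter).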

Compound 4, half-maximal inhibitory concentration: > 100000 nM
Compound 4 ended at the assay's limit (the forecaster's own chance of this, stated with the estimate: 40%); at least 1.2-fold (0.09 log units) between middle value and limit.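

In this assay compound 4 gives > 100000 nM, which is a limit of the assay. Replacing the single aryl ring with naphthalen-2-yl, on the aromatic carbon of the five-membered aromatic ring with 1 nitrogen and 1 sulfur, adds a second ring-size comparison to the small-group exchanges and gives no measurable value: there is an at least 2.3-fold higher number from compound 2 to compound 4 (0.37 log units; beyond the scatter), which separates compound 4 from the 4-(trifluoromethyl)phenyl compound, while an at least 1.4-fold higher number from compound 1 to compound 4 (0.15 log units; that floor lies within the scatter) does not by itself separate it from the 4-fluorophenyl compound. The step between compound 3 and compound 4 cannot be read, as both end at the same limit: the limit of > 100000 nM in this assay, at which 2 of the 4 values shown sit.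

The compounds shown leave open whether any aryl group at this position can give a value clearly apart from those of compound 1 and compound 2, as neither of those lies beyond the scatter of the other. They also leave open how this position reads in this assay with a group of another kind, such as an amine, a carboxylic acid or a longer chain, in place of the aryl ring.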